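Varying the amine substituent on the shared core

This account rests on a few compounds, and the source may have more. Where it says the series, first, only, none or still open, it means among the compounds named here.

Compound 3 `COc1cc(/C=C/C(=O)/C=C(/C=C/c2ccc(O)c(OC)c2)NC2CCCCC2)ccc1O` gives 88% in a functional assay on Caco-2 cells (Homo sapiens), read by fluorescence, tested at 1 uM; on this read-out lower numbers stand for a stronger effect and higher numbers for a weaker effect at the one concentration tested. Compound 1 `CCC(C)NC(=C\C(=O)/C=C/c1ccc(O)c(OC)c1)/C=C/c1ccc(O)c(OC)c1` gives 91% and compound 2 `C=CCNC(=C\C(=O)/C=C/c1ccc(O)c(OC)c1)/C=C/c1ccc(O)c(OC)c1` gives 89% in this assay, so compound 3 holds the lowest of the three numbers, yet within the scatter of both others. The steps of a number 3 percentage points lower from compound 1 to compound 3 (within the scatter), a number 1 percentage points lower from compound 2 to compound 3 (within the scatter) and a number 2 percentage points lower from compound 1 to compound 2 (within the scatter) all bear on the next change, and all three lie within the scatter. Compound 4 `COc1cc(/C=C/C(=O)/C=C(/C=C/c2ccc(O)c(OC)c2)NCC(C)C)ccc1O` differs from compound 3 by isobutyl in place of cyclohexyl on an amine nitrogen. Accordingly, no step beyond the scatter is expected in this assay, in either direction. Compound 4 is expected at 89%, with a range from 81% to 97%. The step expected from this change is a number 1 percentage points higher from compound 3 to compound 4 (within the scatter).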

Compound 4, a percentage reported as activity, at one concentration (the size of the read-out at that concentration, not a potency): 91%
For compound 4 the middle estimate is 2 percentage points below the measured one; the measured number falls inside the stated range.
By their numbers in this assay, from the lowest: compounds 3, 2, 1 and 4 (each within the scatter of the next).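

On the amine nitrogen, isobutyl in place of cyclohexyl swaps a six-membered carbon ring for an open chain and gives a number 3 percentage points higher from compound 3 to compound 4 (within the scatter) in this assay. The other two comparisons read a number 2 percentage points higher from compound 2 to compound 4 (within the scatter) and no change at the digits printed from compound 1 to compound 4 (within the scatter), so with isobutyl added, every step among these four substituents stays within the scatter, with or without the ring. No evidence accompanies this flat result. As far as these compounds go, all four substituents contain carbon and hydrogen only, so a hydroxyethyl, a benzyl or a chain ending in a carboxylic acid on this nitrogen remains open. Also open, from the compounds shown here alone, is whether any change here gives a step beyond the scatter.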